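The compounds below may be only part of what the source reports. "The series", "measured", "known", "first", "only" and "open" are said of these compounds alone.

Measured compounds in an assay on CHO cells for displacement of a labelled ligand from prostaglandin E2 receptor EP3 subtype (Homo sapiens), read by radioligand binding; on this read-out lower numbers stand for stronger inhibition and higher numbers for weaker inhibition:

- compound 1, `CC(C)C(c1ccc(-c2ccc3cccc(F)c3c2)[nH]c1=O)N1CCCCC1=O`: 6.4 nM
- compound 2, `CCn1ncc2c(F)cc(-c3ccc(C(CC)(CC)c4ncn(C)n4)c(=O)[nH]3)cc21`: 39 nM
- compound 3, `CCC(CC)(c1nnc[nH]1)c1ccc(-c2ccc3cccc(F)c3c2)[nH]c1=O`: 19 nM

Compound 1 stands lowest of the three numbers in this assay. Its nearest neighbour is compound 3, whose value lies beyond the scatter of compound 1; compound 2 is further off, also beyond the scatter. Compounds 2 and 3 both carry a five-membered aromatic ring on the saturated chain carbon, and both give higher numbers than compound 1, but no single-change comparison among the measured compounds is available, so these pairs show only their two values.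

Compound 4, `CC(C)C(c1cnc(N)s1)c1ccc(-c2ccc3cccc(F)c3c2)[nH]c1=O`, has not yet been measured in this assay. It differs from compound 1 in one place: 2-amino-1,3-thiazol-5-yl in place of 2-oxopiperidin-1-yl on a saturated chain carbon bound to an aromatic carbon and a saturated chain carbon

The change replaces a six-membered non-aromatic ring with a five-membered aromatic ring that brings one hydrogen-bond donor and two further acceptors. Among the measured compounds shown here, with no matched step on record, the expectation rests on the values alone: a modest move toward a higher number is expected, of a size that may or may not exceed the scatter, with a 2.3-fold higher number from compound 1 to compound 4 (0.37 log units; beyond the scatter) as the estimated step. Compound 4 is accordingly estimated at 15 nM in this assay, with a range from 4 nM to 60 nM.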

Compound 4, inhibition constant: 16 nM
Beside the measured number, compound 4's estimate is 1.1-fold (0.03 log units) below it, and the stated range covers the measured number.
By their numbers in this assay, from the lowest: compound 1; then compounds 4 and 3 (each within the scatter of the next); then compound 2.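

In this assay, among the compounds shown here, the step at this position is the first matched comparison: 2-amino-1,3-thiazol-5-yl in place of 2-oxopiperidin-1-yl on a saturated chain carbon bound to an aromatic carbon and a saturated chain carbon gives a 2.5-fold higher number from compound 1 to compound 4 (0.40 log units; beyond the scatter), a modest move beyond the scatter. For the compounds shown here, the position therefore accepts a five-membered aromatic ring carrying a hydrogen-bond donor in place of a six-membered non-aromatic ring without one, at the cost of only this modest step, with compound 4 at 16 nM. No measurement on hand accounts for the size of this step.

A single pair changes ring size, aromaticity, hetero atoms and hydrogen-bond donor count together, so it cannot show which of these differences carries the step. Also open, from the compounds shown here alone, is where a 1,3-thiazol-5-yl group without the amino group, or an open-chain dimethylamino group, at the same position would fall relative to compound 1 and compound 4.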